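Thiazolidinedione amides against prostate carcinoma cells

The source may report more compounds than this note shows. Statements on the series, on what has been measured and on what is new or still open speak of the compounds shown alone.

In a functional assay on PC-3 cells (Homo sapiens) for cytotoxicity, read by sulforhodamine B assay, with a stated time of 48 h (a lower number here means a stronger inhibitor of growth, a higher number a weaker inhibitor of growth), compound 2 `O=C(COc1ccc(/C=C2\SC(=O)NC2=O)cc1)Nc1nc2ccccc2s1` gives 28200 nM; this is the only number shown for it, a further entry reporting no single value. Compound 1 `Cc1cnc(NC(=O)COc2ccc(/C=C3\SC(=O)NC3=O)cc2)s1` gives 37200 nM; 2240 nM (2 entries) in this assay, and the spread of its repeats, (the several entries of compound 1 in this assay, 37200 nM; 2240 nM (2 entries)), shows how far one measurement can move. Compound 3 `O=C(COc1ccc(/C=C2\SC(=O)NC2=O)cc1)Nc1ncc([N+](=O)[O-])s1` carries 5-nitro-1,3-thiazol-2-yl in place of 1,3-benzothiazol-2-yl on an amide-type nitrogen. For the measured compounds named here, no measured pair isolates this change; the step is expected to be modest and towards stronger growth inhibition, a 1.9-fold lower number from compound 2 to compound 3 (0.27 log units; within the scatter). Compound 3 is accordingly estimated at 15000 nM, within 3000 nM to 60000 nM.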

Compound 3, concentration for 50% growth inhibition: < 100000 nM
Compound 3 ended at the assay's limit; the forecaster's own chance of this, stated with the estimate: 15%; the middle value does not contradict the limit.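

Compound 3 gives < 100000 nM, which is a limit and not a number. No step can be read between compound 2 and compound 3. As far as these compounds go, whether 5-nitro-1,3-thiazol-2-yl in place of 1,3-benzothiazol-2-yl alters growth inhibition stays open.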